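Aryl urea variation on the dichloro series: compound 4

The compounds below may be only part of what the source reports. "The series", "measured", "known", "first", "only" and "open" are said of these compounds alone.

Compound 3 `CN(C)CCCNc1nc(-c2ccc(NC(=O)Nc3ccccc3Cl)cc2)nc2c(Cl)c(Cl)sc12` in a functional assay on NCI-H460 cells (Homo sapiens) for cytotoxicity, read by MTT assay, with a stated time of 72 h (a higher number here means a weaker inhibitor, a lower number a stronger inhibitor), gives 490 nM, the lowest of the three numbers in hand, though all three sit within the scatter of one another. Compound 1 `CN(C)CCCNc1nc(-c2ccc(NC(=O)Nc3ccccc3F)cc2)nc2ccsc12` gives 530 nM, and compound 2 `CN(C)CCCNc1nc(-c2ccc(NC(=O)Nc3ccc(F)cc3)cc2)nc2c(Cl)c(Cl)sc12` gives 650 nM. Compound 1 differs from compound 3 in two places rather than one, so its value and that of compound 3 are only set side by side without a step. Among the measured compounds shown here, the single one-point step in the set, a 1.3-fold lower number from compound 2 to compound 3 (0.12 log units; within the scatter), is the only one that concerns the aryl group on the urea.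

Compound 4 `Cc1ccc(NC(=O)Nc2ccc(-c3nc(NCCCN(C)C)c4sc(Cl)c(Cl)c4n3)cc2)cc1` differs from compound 3 by 4-methylphenyl in place of 2-chlorophenyl on an amide-type nitrogen. For the measured compounds named here, the one comparable step, between compound 2 and compound 3, lay within the scatter, and compound 1 with a third aryl group also gives a number close to these; nothing in the set points to movement in either direction. Accordingly the expected step in this assay is a 1.1-fold higher number from compound 3 to compound 4 (0.05 log units; within the scatter), not beyond the scatter. Compound 4 is therefore estimated at 550 nM, with a range from 250 nM to 1200 nM.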

Compound 4, half-maximal inhibitory concentration: 1110 nM
Beside the measured number, compound 4's estimate is 2.0-fold (0.30 log units) below it; the measured number falls inside the stated range.
By their numbers in this assay, from the lowest: compounds 3, 1, 2 and 4 (each within the scatter of the next, the first and the last beyond it).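

In this assay the aryl group on the urea gives its first step beyond the scatter: a 2.3-fold higher number from compound 3 to compound 4 (0.36 log units; beyond the scatter), a modest step for 4-methylphenyl in place of 2-chlorophenyl on an amide-type nitrogen. The other new step, a 1.7-fold higher number from compound 2 to compound 4 (0.23 log units; within the scatter), for methyl in place of fluoro on an aromatic carbon, stays within the scatter, so 4-methylphenyl and 4-fluorophenyl are not told apart here. No measurement available here bears on the reason for either step.

The step from 2-chlorophenyl to 4-methylphenyl changes both the substituent and its place on the ring, so 2-methylphenyl and 4-chlorophenyl on the same nitrogen would be needed to separate the two. Going by these compounds, how an aryl group carrying an amine or a carboxylic acid would read in this assay also remains open.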